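The compounds below may be only part of what the source reports. "The series", "measured", "known", "first", "only" and "open" are said of these compounds alone.

Compound 1 `O=C(Nc1cccc(CNc2nccnc2Cl)c1)Nc1cccc2ccccc12`: in a functional assay on HepG2 cells (Homo sapiens) for antiproliferative activity, read by MTT assay, with a stated time of 48 h (a higher number here means a weaker inhibitor, a lower number a stronger inhibitor), compound 1 gives > 40000 nM, which is a limit of the assay.
Compound 2 `CCOc1ccc(NC(=O)Nc2cccc(CNc3nccnc3Cl)c2)cc1`: in this assay compound 2 gives 7050 nM.

Going by the values given here, compound 2 holds the only number measured so far; the other result, (the limit of > 40000 nM in this assay, at which 1 of the 2 values shown sits), is a limit and not a number. Compound 3 `O=C(Nc1cccc(CNc2nccnc2Cl)c1)Nc1ccccc1F` has not yet been measured in this assay. It differs from compound 2 by 2-fluorophenyl in place of 4-ethoxyphenyl on an amide-type nitrogen. Among the compounds with values here, no measured step between two compounds is available, so the size of this change is uncertain; a modest step toward weaker inhibition is expected, a 2.1-fold higher number from compound 2 to compound 3 (0.33 log units; beyond the scatter). Compound 3 is therefore expected at about 15000 nM, between 4000 nM and 50000 nM, with a real chance that only a limit is reported.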

Compound 3, half-maximal inhibitory concentration: 10500 nM
The estimate for compound 3 lay 1.4-fold (0.15 log units) above the measured number, within the range that was stated.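

In this assay, going by these compounds alone, the first step at this amide-type nitrogen is a 1.5-fold higher number from compound 2 to compound 3 (0.17 log units; within the scatter), so compound 2 and compound 3 cannot be told apart, and 2-fluorophenyl serves here as well as 4-ethoxyphenyl. Compound 1 gives > 40000 nM, which is a limit and not a number, so its steps to the other two cannot be read. Nothing measured here accounts for the match between compound 2 and compound 3. From the compounds shown here alone, it remains open how a cyclohexyl group or a short alkyl chain would read at this nitrogen. Also open, going by these compounds, is what an amine or a carboxylic acid on the phenyl ring would do.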